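A few compounds are considered here, and "the series" means these few. Any claim that something is new, unique, unknown or untested is made for them only; others in the source may bear on it.

Series notes. The shared core of compound 1 `Nc1ccccc1NC(=O)c1ccc(CSC(=S)N2CCN(c3ccccc3)CC2)cc1` is kept across the set; the variable part sits on the thiocarbonyl carbon. In a functional assay on HeLa cells (Homo sapiens) for antiproliferative activity, read by CCK-8 assay, with a stated time of 72 h, tested at 2 uM (a lower number here means a weaker effect, a higher number a stronger effect of the compound at the concentration tested), compound 1 gives 62.2%, the highest of the three numbers measured. Going by the values given here, compound 2 `Nc1ccccc1NC(=O)c1ccc(CSC(=S)N2CCc3ccccc32)cc1` gives 38% in this assay, and compound 3 `CC1CCN(C(=S)SCc2ccc(C(=O)Nc3ccccc3N)cc2)CC1` gives 46.8%; the one step between measured compounds, a number 8.8 percentage points higher from compound 2 to compound 3 (within the scatter), replaces 2,3-dihydro-1H-indol-1-yl with 4-methylpiperidin-1-yl on the thiocarbonyl carbon and stays within the scatter. Compound 1 stands clear of both, beyond the scatter in each case.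

Compound 4 `Cc1ccc(N2CCN(C(=S)SCc3ccc(C(=O)Nc4ccccc4N)cc3)CC2)cc1` differs from compound 1 only by methyl in place of hydrogen on an aromatic carbon, read one bond further out as phenyl to 4-methylphenyl. Among the compounds with values here, no measured step touches this place: the step from compound 2 to compound 3 changes the group on the thiocarbonyl carbon, not a substituent on a six-membered aromatic ring of carbon only. With nothing to point either way, the step expected is a number 2.2 percentage points lower from compound 1 to compound 4 (within the scatter), none beyond the scatter. Compound 4 is therefore estimated at 60%, in the range 45% to 75%.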

Compound 4, a percentage reported as inhibition, at one concentration (the size of the read-out at that concentration, not a potency): 25.3%
Estimate against measurement, compound 4: 34.7 percentage points above; the measured number lies below the stated range.
By their numbers in this assay, from the lowest: compound 4; then compounds 2 and 3 (each within the scatter of the next); then compound 1.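

In this assay, the phenyl group of compound 1 proves sensitive to change: methyl in place of hydrogen on an aromatic carbon, para to a large group, gives a number 36.9 percentage points lower from compound 1 to compound 4 (beyond the scatter). The earlier step replaced one whole group on the thiocarbonyl carbon with another and gave a number 8.8 percentage points higher from compound 2 to compound 3 (within the scatter), whereas here a single added heavy atom produces a step beyond the scatter, so the size of a change does not track the size of its effect in these two steps. Nothing at hand accounts for this step, and its cause remains unknown.

From the compounds shown here alone, it remains open whether this step is particular to methyl or would also follow from a chlorine atom, a methoxy group or an amine at the same place. A single concentration also leaves open how compound 1 and compound 4 compare in potency.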